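Cyano in place of methoxy: an expected step

The compounds below may be only part of what the source reports. "The series", "measured", "known", "first", "only" and "open" are said of these compounds alone.

In an ADME assay (liver) for metabolic stability, with Liver microsome (Rattus norvegicus) as the target, read by LC-MS, using microsomes, with a stated time of 30 min, tested at 4 uM (a lower number here means that less of the compound is left, a higher number that more of the compound is left), compound 1 (`Cc1nc(N2CCN(C)CC2)c2nc(-c3cccc(Cl)c3)n(C3CCOCC3)c2n1`) gives 45% and compound 2 (`COc1ccccc1-c1nc2c(N3CCN(C)CC3)nc(C)nc2n1C1CCOCC1`) gives 35%, which lie within the usual scatter of each other. Compound 3 (`Cc1nc(N2CCN(C)CC2)c2nc(-c3ccccc3C#N)n(C3CCOCC3)c2n1`) has cyano in place of methoxy on an aromatic carbon. Among the compounds with values here, only one measured step bears on this change: a number 10 percentage points lower from compound 1 to compound 2 (within the scatter), which alters the same group. Within the data shown here, no measured compound yet carries cyano, so no step beyond the scatter is expected. The estimated step is a number 7 percentage points higher from compound 2 to compound 3 (within the scatter). For compound 3 the expected value is 42%, with an estimated range of 25% to 60%.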

Compound 3, percent of the compound remaining: 21%
Estimate against measurement, compound 3: 21 percentage points above; the measured number lies below the stated range.
By their numbers in this assay, from the lowest: compound 3; then compounds 2 and 1 (each within the scatter of the next).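

The group on this aromatic carbon can move the result beyond the usual scatter in this assay: cyano in place of methoxy gives a number 14 percentage points lower from compound 2 to compound 3 (beyond the scatter), and 2-cyanophenyl in place of 3-chlorophenyl gives a number 24 percentage points lower from compound 1 to compound 3 (beyond the scatter). Methoxy and cyano have matching counts of heavy atoms and hydrogen-bond acceptors, so those counts alone do not settle the result here. No measurement shown explains the lower number for compound 3. On these data alone, whether an amine, a carboxylic acid or a longer chain at this place would leave more of the compound remains open. So does whether cyano would give a similar step if another part of the shared core were changed.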